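Fluoro Added to Compound 3's Phenyl Ring

The source may report more compounds than this note shows. Statements on the series, on what has been measured and on what is new or still open speak of the compounds shown alone.

Compound 1 `Cc1ccc(-n2cc(-c3ccccc3NS(=O)(=O)c3c[nH]c(=O)[nH]c3=O)nn2)cc1` gives 6390 nM in a functional assay on SGC-7901 cells (Homo sapiens) for antiproliferative activity, read by MTT assay, with a stated time of 24 h; on this read-out higher numbers stand for weaker inhibition and lower numbers for stronger inhibition. Compound 2 `Cc1cccc(-n2cc(-c3cccc(NS(=O)(=O)c4c[nH]c(=O)[nH]c4=O)c3)nn2)c1` gives 9100 nM in this assay. Compound 3 `O=c1[nH]cc(S(=O)(=O)Nc2ccc(-c3cn(-c4ccccc4)nn3)cc2)c(=O)[nH]1` gives 18800 nM in this assay.

Compound 3 therefore stands highest of the three numbers, which means it is the weakest inhibitor of the set: its nearest neighbour is compound 2, whose number is lower by a gap that goes beyond the scatter of repeated measurements, and compound 1 lies further away still, also beyond the scatter.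

Compound 4 `O=c1[nH]cc(S(=O)(=O)Nc2ccc(-c3cn(-c4ccccc4F)nn3)cc2)c(=O)[nH]1` has not yet been measured. It differs from compound 3 in one place: fluoro in place of hydrogen on an aromatic carbon. Among the measured compounds shown here, a single fluorine on the phenyl ring, ortho to a large group, is a small change, and no comparable step between measured compounds is available to show how the number moves. The expected step from compound 3 to compound 4 is therefore small, a 1.3-fold lower number from compound 3 to compound 4 (0.10 log units; within the scatter), in no clear direction beyond the scatter. Compound 4 is estimated at 15000 nM, with a range from 6000 nM to 40000 nM in this assay.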

Compound 4, half-maximal inhibitory concentration: 7270 nM
Estimate against measurement, compound 4: 2.1-fold (0.31 log units) above, and the stated range covers the measured number.
By their numbers in this assay, from the lowest: compounds 1, 4 and 2 (each within the scatter of the next); then compound 3.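

In this assay, fluoro in place of hydrogen on an aromatic carbon, ortho to a large group, gives a 2.6-fold lower number from compound 3 to compound 4 (0.41 log units; beyond the scatter) on a read-out where a lower number means stronger inhibition. Among the compounds shown here, the earlier compounds offered no pair differing in one place, so this is the first sign that this phenyl ring responds to a change as small as one added heavy atom. Nothing available here bears on why the number moves.

On these data alone, it remains open whether the step belongs to fluoro itself or whether another group at the same place, such as chloro, methoxy or an amine, would move the number as far. Also open, as far as these compounds go, is whether fluoro on another carbon of this ring would give a similar step, so one pair cannot yet describe a trend.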